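The compounds below may be only part of what the source reports. "The series", "measured", "known", "first", "only" and "open" are said of these compounds alone.

Compound 3 `O=C1NC(=O)/C(=C/c2ccc(OCCSc3nnc(-c4ccc(Cl)cc4)[nH]3)cc2)S1` gives 19.6% in a functional assay on the whole organism (plasma, strain Wistar) with Rattus norvegicus as the target, with a stated time of 15 days, at a dose of 10 mg/kg by the oral route; on this read-out lower numbers stand for a weaker effect and higher numbers for a stronger effect at the one dose given. Compound 1 `O=C1NC(=O)/C(=C/c2ccc(OCCSc3nnc(-c4ccccc4)[nH]3)cc2)S1` gives 10.6% in this assay, and compound 2 `Cc1ccc(-c2nnc(SCCOc3ccc(/C=C4\SC(=O)NC4=O)cc3)[nH]2)cc1` gives 20.4% in this assay, so compound 3 stands among three numbers that do not separate from one another. Compound 4 `COc1ccc(-c2nnc(SCCOc3ccc(/C=C4\SC(=O)NC4=O)cc3)[nH]2)cc1` differs from compound 3 by methoxy in place of chloro on an aromatic carbon. Within the data shown here, no measured compound carries a methoxy, so the steps that bear on this position are those at the same aromatic carbon: a number 9 percentage points higher from compound 1 to compound 3 (within the scatter), a number 0.8 percentage points lower from compound 2 to compound 3 (within the scatter) and a number 9.8 percentage points higher from compound 1 to compound 2 (within the scatter), none of them beyond the scatter. Compound 4 is therefore expected to show a number 2.6 percentage points lower from compound 3 to compound 4 (within the scatter), nothing beyond the scatter. The estimate for compound 4 in this assay is 17%, within a range from 7% to 28%.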

Compound 4, a percentage reported as activity, at one dose (the size of the read-out at that dose, not a potency): 33.6%
Compound 4: middle estimate off by 16.6 percentage points, on the low side; measured number above the stated range.
By their numbers in this assay, from the lowest: compounds 1, 3 and 2 (each within the scatter of the next); then compound 4.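

In this assay this position, where hydrogen, methyl and chloro did not separate, now gives a clear difference: there is a number 14 percentage points higher from compound 3 to compound 4 (beyond the scatter), a number 13.2 percentage points higher from compound 2 to compound 4 (beyond the scatter) and a number 23 percentage points higher from compound 1 to compound 4 (beyond the scatter). Methoxy is thus the only one of the four groups with steps beyond the scatter to all the others, and the exchange for chloro adds one hydrogen-bond acceptor by count. Nothing measured here explains this rise. From the compounds shown here alone, whether a hydroxy group, an ethoxy group or an amine on the same aromatic carbon would match methoxy or fall with the other three remains open.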